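The source may hold more compounds than are shown below. What is called first, only, known or untested is meant among the compounds shown, and "the series" means these compounds.

Measured so far:
- Compound 1, `O=C(Nc1cccc2nonc12)N1CCN(Cc2cccc(Oc3ccc(Cl)cc3)c2)CC1`: 28 nM
- Compound 2, `O=C(Nc1noc2ccncc12)N1CCN(Cc2cccc(Oc3ccc(Cl)cc3)c2)CC1`: 180 nM

Two compounds share a core and differ only in the group on the amide-type nitrogen. In an assay on isolated protein for inhibition of Fatty-acid amide hydrolase 1 (Homo sapiens), with a stated time of 60 min (a higher number here means a weaker inhibitor, a lower number a stronger inhibitor), compound 1 gives 28 nM, while compound 2 gives 180 nM; the step of a 6.4-fold higher number from compound 1 to compound 2 (0.81 log units; beyond the scatter) is a loss of potency beyond the scatter, and compound 2 therefore stands at the weaker end of the two numbers seen so far.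

Compound 3, `O=C(Nc1noc2cccnc12)N1CCN(Cc2cccc(Oc3ccc(Cl)cc3)c2)CC1`, has not yet been measured. It is built from exactly the same atoms as compound 2, joined differently: a group of 9 heavy atoms (6 carbon, 2 nitrogen, 1 oxygen; one five-membered aromatic ring with 2 hetero atoms, one six-membered aromatic ring with 1 hetero atom) in place of a group of 9 heavy atoms (6 carbon, 2 nitrogen, 1 oxygen; one five-membered aromatic ring with 2 hetero atoms, one six-membered aromatic ring with 1 hetero atom), on an amide-type nitrogen. Among the measured compounds shown here, no measured step covers such a swap between two isomeric groups of this kind; the only step available, from compound 1 to compound 2, exchanges one ring type for another and is not a direct guide here. Without a matching precedent, the expectation for compound 3 in this assay is a number close to that of compound 2, with a 1.1-fold lower number from compound 2 to compound 3 (0.05 log units; within the scatter) expected to fall within the scatter. The estimate for compound 3 is 160 nM, in a range from 50 nM to 500 nM.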

Compound 3, half-maximal inhibitory concentration: 13 nM
For compound 3 the middle estimate is 12-fold (1.09 log units) above the measured one, outside the stated range (below it).
By their numbers in this assay, from the lowest: compound 3; then compound 1; then compound 2.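

In this assay the group on the amide-type nitrogen matters through how its atoms are joined and not only through which atoms it holds: rearranging them gives a 14-fold lower number from compound 2 to compound 3 (1.14 log units; beyond the scatter) even though both groups have the same counts of atoms, rings, hydrogen-bond donors and hydrogen-bond acceptors. Compound 3 also goes past the earlier best compound, with a 2.2-fold lower number from compound 1 to compound 3 (0.33 log units; beyond the scatter) so the type of group that seemed the poorer choice when only compound 2 represented it can in fact give the lowest number of the three. No measured information shown here explains why joining the same atoms differently has so large an effect.

As far as these compounds go, all three compounds carry the same remainder of the molecule, so it stays open whether the gain from this rearrangement would persist with a different group in place of the chlorine, such as a fluorine or a methyl. From the compounds shown here alone, it is also open whether adding a small group such as a methyl or a methoxy to the six-membered ring of the group in compound 3 would keep its potency.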